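A few compounds are considered here, and "the series" means these few. Any claim that something is new, unique, unknown or untested is made for them only; others in the source may bear on it.

Measured so far:
compound 1 `Cc1ccc2c(c1)c([C@H](C)Nc1ncnc3[nH]cnc13)nn2-c1cccnc1` — 18%
compound 2 `C[C@H](Nc1ncnc2[nH]cnc12)c1nn(-c2cccc(F)c2)c2cc(F)ccc12` — 33%

In a functional assay on HepG2 cells (Homo sapiens) for inhibition, read by sulforhodamine B assay, with a stated time of 72 h, tested at 10 uM (a higher number here means more inhibition at the concentration tested (going by the name of the read-out), a lower number less inhibition), compound 2 stands highest of the two numbers; the nearest value, that of compound 1, lies lower, beyond the scatter. Compound 3 `C[C@H](Nc1ncnc2[nH]cnc12)c1nn(-c2cccnc2)c2cc(F)ccc12` differs from compound 2 by pyridin-3-yl in place of 3-fluorophenyl on an aromatic nitrogen. Compound 1 also carries pyridin-3-yl on that aromatic nitrogen and in this assay compound 1 gives 18%. A modest downward step is therefore expected, a number 9 percentage points lower from compound 2 to compound 3 (within the scatter), at the edge of the scatter. Compound 3 is estimated at 24%, with a range from 10% to 40%.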

Compound 3, a percentage reported as inhibition, at one concentration (the size of the read-out at that concentration, not a potency): 23%
For compound 3 the middle estimate is 1 percentage points above the measured one; low and high end bracket the measured number.
By their numbers in this assay, from the lowest: compounds 1, 3 and 2 (each within the scatter of the next, the first and the last beyond it).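

In this assay, among these compounds, the swap of 3-fluorophenyl for pyridin-3-yl on the aromatic nitrogen gives a number 10 percentage points lower from compound 2 to compound 3 (within the scatter) and is the first reading of this change alone, since compound 1 and compound 2 differ in more than one place. At this position, a ring nitrogen with its hydrogen-bond acceptor in place of the fluorinated carbon ring therefore leaves the number within the scatter. No measurement here offers an explanation for this result.

Open, on these data alone, is whether a morpholine ring or a short alkyl chain on that nitrogen would move the number beyond the scatter.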